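Nitro for fluoro on the nitroaryl arm of the series

A few compounds are considered here, and "the series" means these few. Any claim that something is new, unique, unknown or untested is made for them only; others in the source may bear on it.

Measured compounds in a functional assay on CCRF-CEM cells (Homo sapiens) for cytotoxicity, in the absence of a further agent; on this read-out lower numbers stand for stronger inhibition and higher numbers for weaker inhibition:
compound 1 `Nc1nc(N)c(CCCN(Cc2ccc(NC(CCC(=O)O)C(=O)O)cc2)c2cc(F)cc(F)c2[N+](=O)[O-])c(O)n1` — > 100000 nM
compound 2 `Nc1nc(N)c(CCCN(Cc2ccc(NC(CCC(=O)O)C(=O)O)cc2)c2cc(F)c(F)cc2[N+](=O)[O-])c(O)n1` — > 100000 nM

Both values shown are limits of this assay, not numbers. For compound 2 the value > 100000 nM is a limit. For compound 1 the value > 100000 nM is likewise a limit. Among the compounds with values here, the single step, 4,5-difluoro-2-nitrophenyl in place of 3,5-difluoro-2-nitrophenyl on an amine nitrogen, a step that the two limits leave unreadable from compound 1 to compound 2, cannot be read, since the limit of > 100000 nM in this assay, at which 2 of the 2 values shown sit, holds both ends of it. Compound 2 therefore stands only at a limit, with no number of its own.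

Compound 3 `Nc1nc(N)c(CCCN(Cc2ccc(NC(CCC(=O)O)C(=O)O)cc2)c2cc(F)c([N+](=O)[O-])cc2[N+](=O)[O-])c(O)n1` differs from compound 2 by nitro in place of fluoro on an aromatic carbon: fluoro leaves and nitro enters, on an aromatic carbon of a six-membered aromatic ring of carbon only. No measured step bears on this change, and the one step shown is unreadable. For compound 3 the step of a number no higher from compound 2 to compound 3 (the limit leaves the size open) is expected to be none readable beyond the scatter. Compound 3 is estimated at 100000 nM, within 30000 nM to 300000 nM, most likely again reported only as a limit.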

Compound 3, half-maximal inhibitory concentration: 51000 nM
Compound 3: middle estimate off by 2.0-fold (0.29 log units), on the high side; low and high end bracket the measured number.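

In this assay, the swap to a nitro group at this aromatic carbon, ortho to a fluoro group and para to a large group, gives the series its first number rather than a limit: compound 3 gives 51000 nM. The change reads as an at least 1.9-fold lower number from compound 2 to compound 3 (0.29 log units; that floor lies within the scatter), so it sets only a floor and does not show a change beyond the scatter. The true size of the step stays open because one end of it is a limit: the limit of > 100000 nM in this assay, at which 2 of the 3 values shown sit.

On these data alone, whether an amine, a nitrile or a carboxylic acid at this same carbon would also give a number remains open. Also open, as far as these compounds go, is whether nitro in place of fluoro would give a comparable result on the differently substituted arm of compound 1.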